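Moving a Methyl Group on the Pyrazole Ring

This account rests on a few compounds, and the source may have more. Where it says the series, first, only, none or still open, it means among the compounds named here.

Of the compounds shown here, three that share one core have been measured in an assay on HEK293 cells for inhibition of Leucine-rich repeat serine/threonine-protein kinase 2 (Homo sapiens), with a stated time of 48 h; on this read-out lower numbers stand for stronger inhibition and higher numbers for weaker inhibition. Compound 1 `Cc1nn(C)cc1Nc1nc(N)c2c(C#N)c(N3CCC[C@H]3C)n(C)c2n1` gives 190 nM. Compound 2 `C[C@@H]1CCCN1c1c(C#N)c2c(N)nc(Nc3cn(C)nc3C(F)(F)F)nc2n1C` gives 910 nM; here the step of a 4.8-fold higher number from compound 1 to compound 2 (0.68 log units; beyond the scatter) follows from a trifluoromethyl in place of methyl on an aromatic carbon. Compound 3 `Cc1c(Nc2nc(N)c3c(C#N)c(N4CCC[C@H]4C)n(C)c3n2)cnn1C1COC1` gives 300 nM, the second highest of the three numbers: the step of a 1.6-fold higher number from compound 1 to compound 3 (0.20 log units; within the scatter) stays within the scatter, while the step of a 3.0-fold lower number from compound 2 to compound 3 (0.48 log units; beyond the scatter) lies beyond it.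

Compound 4 `Cc1nn(C2COC2)cc1Nc1nc(N)c2c(C#N)c(N3CCC[C@H]3C)n(C)c2n1` is built from the same atoms as compound 3, joined differently: 3-methyl-1-(oxetan-3-yl)-1H-pyrazol-4-yl in place of 5-methyl-1-(oxetan-3-yl)-1H-pyrazol-4-yl on a nitrogen on an aromatic ring. Among the measured compounds shown here, no measured pair isolates this change on its own. The nearest guide is the step of a 1.6-fold higher number from compound 1 to compound 3 (0.20 log units; within the scatter), which combines this same change with an oxetanyl in place of methyl on the ring nitrogen and stays within the scatter. Compound 4 carries the methyl placement of compound 1 together with the oxetanyl of compound 3, so its number is expected to land between the values of those two compounds. Compound 4 is therefore estimated at 230 nM, with a range from 110 nM to 480 nM. The expected step is a 1.3-fold lower number from compound 3 to compound 4 (0.12 log units; within the scatter), which is none beyond the scatter.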

Compound 4, half-maximal inhibitory concentration: 240 nM
The estimate for compound 4 lay 1.0-fold (0.02 log units) below the measured number; measured number inside the range.
By their numbers in this assay, from the lowest: compounds 1, 4 and 3 (each within the scatter of the next); then compound 2.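

In this assay, exchanging 5-methyl-1-(oxetan-3-yl)-1H-pyrazol-4-yl for 3-methyl-1-(oxetan-3-yl)-1H-pyrazol-4-yl gives a 1.3-fold lower number from compound 3 to compound 4 (0.10 log units; within the scatter), so with oxetan-3-yl held constant, the placement of the methyl group has no effect that can be read from these data. Compound 4 also separates out a change that was mixed with the methyl placement in the earlier comparison: oxetan-3-yl in place of methyl on an aromatic nitrogen gives a 1.3-fold higher number from compound 1 to compound 4 (0.10 log units; within the scatter), so this exchange also stays within the usual scatter. In contrast, the exchange linking the trifluoromethyl compound with the new isomer gives a 3.8-fold lower number from compound 2 to compound 4 (0.58 log units; beyond the scatter), which lies beyond the scatter and leaves compound 2 apart from the other three compounds.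

Nothing available here explains why these steps have the sizes they do. The compounds shown leave open how a piperidin-4-yl or a 2-hydroxyethyl group on the aromatic nitrogen would compare with oxetan-3-yl, and whether an amine or a chlorine atom in place of the methyl group would shift the number as far as trifluoromethyl does.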